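The compounds below may be only part of what the source reports. "The series", "measured", "known", "first", "only" and "open" are said of these compounds alone.

Measured compounds in a functional assay on Maver1 cells (Homo sapiens) for inhibition, read by luminescence and CellTiter-Glo, with a stated time of 72 h; a lower number here means a stronger inhibitor, a higher number a weaker inhibitor:
compound 1 `C/C=C/C(=O)Nc1ccc(Cn2nc(-c3ccc(Oc4ccccc4)cc3)cc2C(=O)O)cc1` gives > 60000 nM, a limit of the assay.
compound 2 `O=C(CCl)Nc1ccc(Cn2nc(-c3ccc(Oc4ccccc4)cc3)cc2CO)cc1` gives 400 nM.
compound 3 `C/C=C/C(=O)Nc1ccc(Cn2nc(-c3ccc(Oc4ccccc4)cc3)cc2C(=O)OCC)cc1` gives > 60000 nM, a limit of the assay.

Compound 3 stands at the limit of this assay; its reading is not a number. The step that the two limits leave unreadable from compound 1 to compound 3 cannot be read either, since both of its ends sit at the same limit (the limit of > 60000 nM in this assay, at which 2 of the 3 values shown sit). Among the measured compounds shown here, compound 2, the only measured compound with a number, carries a hydroxymethyl group on the shared core together with a chloroacetamide.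

The unmeasured compound 4 `C/C=C/C(=O)Nc1ccc(Cn2nc(-c3ccc(Oc4ccccc4)cc3)cc2CO)cc1` differs from compound 3 by hydroxymethyl in place of ethoxycarbonyl on an aromatic carbon. For the measured compounds named here, no measured step bears directly on this change: the single readable number in this assay belongs to compound 2, which shares the hydroxymethyl group with compound 4 but carries a different amide, and no step between compound 2 and compound 4 has been computed here. Compound 3 itself gives only a limit, so the size of the step to compound 4 is open from both sides. Given that compound 2, the sole hydroxymethyl compound measured, gives 400 nM, compound 4 is expected to return a number rather than a limit, with the step of an at least 20-fold lower number from compound 3 to compound 4 (1.30 log units; beyond the scatter) expected to run toward stronger inhibition. The estimate for compound 4 is 3000 nM, with a range from 300 nM to 40000 nM.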

Compound 4, half-maximal inhibitory concentration: 48400 nM
For compound 4 the middle estimate is 16-fold (1.21 log units) below the measured one; measured number outside the range, above it.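

In this assay, the change at this position moves little that can be read: hydroxymethyl in place of ethoxycarbonyl gives an at least 1.2-fold lower number from compound 3 to compound 4 (0.09 log units; that floor lies within the scatter), and hydroxymethyl in place of carboxy gives an at least 1.2-fold lower number from compound 1 to compound 4 (0.09 log units; that floor lies within the scatter). The large readable shift lies on the amide instead: with hydroxymethyl held on the five-membered aromatic ring, prop-1-en-1-yl in place of chloromethyl on the carbonyl carbon gives a 120-fold higher number from compound 2 to compound 4 (2.08 log units; beyond the scatter). Hydroxymethyl therefore does not bring the number of compound 2 with it, and among these compounds the only step clearly beyond the scatter is the one at the amide, not the one on the aromatic carbon.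

On these data alone, how far compound 1 and compound 3 truly lie from compound 4 stays open, as their readings are limits and not numbers: the limit of > 60000 nM in this assay, at which 2 of the 4 values shown sit. Also open, as far as these compounds go, is whether an aminomethyl group or a longer hydroxyalkyl chain on this aromatic carbon would read differently from hydroxymethyl, and whether the chloroacetamide would hold its number with carboxy or ethoxycarbonyl in that place.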